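Swapping the piperazine substituent in a benzamide series

The compounds below may be only part of what the source reports. "The series", "measured", "known", "first", "only" and "open" are said of these compounds alone.

Measured compounds:
- compound 1, `Nc1ccccc1NC(=O)c1ccc(CSC(=S)N2CCN(Cc3ccccn3)CC2)cc1`: 20.7%
- compound 2, `Nc1ccccc1NC(=O)c1ccc(CSC(=S)N2CCN(C3CCCCC3)CC2)cc1`: 31.7%
- compound 3, `Nc1ccccc1NC(=O)c1ccc(CSC(=S)N2CCN(Cc3ccncc3)CC2)cc1`: 33.1%

All three share one core and differ only in the group on an amine nitrogen in a ring. In a functional assay on A-375 cells (Homo sapiens) for antiproliferative activity, read by CCK-8 assay, with a stated time of 72 h, tested at 2 uM (on this read-out lower numbers stand for a weaker effect and higher numbers for a stronger effect at the one concentration tested), compound 3 gives the highest of the three numbers; compound 2 lies close to it, within the scatter, while compound 1 lies furthest away, beyond the scatter.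

Compound 4, `COc1ccc(N2CCN(C(=S)SCc3ccc(C(=O)Nc4ccccc4N)cc3)CC2)cc1`, is not yet measured. It differs from compound 3 by 4-methoxyphenyl in place of (pyridin-4-yl)methyl on an amine nitrogen in a ring.

The steps seen so far bear only loosely on this change. Replacing the group on that nitrogen gave a number 11 percentage points higher from compound 1 to compound 2 (beyond the scatter) and a number 12.4 percentage points higher from compound 1 to compound 3 (beyond the scatter), both modest, whereas a number 1.4 percentage points higher from compound 2 to compound 3 (within the scatter) stayed within the scatter. Two quite different groups, cyclohexyl and (pyridin-4-yl)methyl, thus gave nearly the same number, which suggests that this position tolerates change without large swings. Compound 4 is therefore expected to stay near compound 3, with an expected step of a number 3.1 percentage points lower from compound 3 to compound 4 (within the scatter) in this assay. The estimate for compound 4 is 30%, with a range from 15% to 48%.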

Compound 4, a percentage reported as inhibition, at one concentration (the size of the read-out at that concentration, not a potency): 28.1%
Beside the measured number, compound 4's estimate is 1.9 percentage points above it; measured number inside the range.
By their numbers in this assay, from the lowest: compounds 1, 4, 2 and 3 (each within the scatter of the next, the first and the last beyond it).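

Compound 4 carries 4-methoxyphenyl, whose six-membered aromatic ring is of carbon only, and in this assay the step is a number 5 percentage points lower from compound 3 to compound 4 (within the scatter), while the step against the saturated ring of compound 2 is a number 3.6 percentage points lower from compound 2 to compound 4 (within the scatter); the hetero atom of the aromatic ring in compound 3 can thus be replaced here without a shift beyond the scatter, and an aromatic ring of carbon only fits with the two groups already seen. The third step is a number 7.4 percentage points higher from compound 1 to compound 4 (within the scatter), so compound 4 lies within the scatter of compound 1 as well as of compounds 2 and 3, and it does not sharpen the one gap beyond the scatter, that between compound 1 and compound 3. No measurement shown here offers an explanation for these small steps.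

From the compounds shown here alone, it remains open whether a carboxylic acid, a primary amine or a longer alkyl chain on the same nitrogen would move the number beyond the scatter. Going by these compounds, each number also comes from a single concentration, so how these compounds compare in potency remains open too.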